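The source may hold more compounds than are shown below. What is called first, only, known or untested is meant among the compounds shown, and "the series" means these compounds.

Compound 1 `COc1ncc(-c2ccccc2)cc1[C@@H](c1ccccc1)[C@@](O)(CCN(C)C)c1cc(F)ccc1F` has no measured number in a toxicity assay on HeLa cells (Homo sapiens) for cytotoxicity; a lower number here means that less compound is tolerated, a higher number that more compound is tolerated: its entry reads "nd" (no result reported), meaning that no result was reported for compound 1. Two related compounds were tested. Compound 2 `COc1nc(-c2ccc(F)cc2)ccc1[C@@H](c1ccccc1)[C@@](O)(CCN(C)C)c1cccc2ccccc12` reaches only a limit of this assay, giving > 64 ug/mL. Compound 3 `COc1ccc(-c2ccc([C@@H](c3ccccc3)[C@@](O)(CCN(C)C)c3cccc4ccccc34)c(OC)n2)cc1` likewise reaches only a limit, giving > 64 ug/mL. Among the measured compounds shown here, the one measured step, a step that the two limits leave unreadable from compound 2 to compound 3, therefore cannot be read in size, and the only firm point in these data is the limit of > 64 ug/mL in this assay, at which 2 of the 3 values shown sit.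

Compound 4 `COc1ncc(-c2ccccc2)cc1[C@@H](c1ccccc1)[C@@](O)(CCN(C)C)c1cccc2ccccc12` differs from compound 1 by naphthalen-1-yl in place of 2,5-difluorophenyl on a saturated chain carbon bound to an oxygen on a saturated carbon and two saturated chain carbons. For the measured compounds named here, no measured step covers this change, and the single step that exists says nothing about size, so it offers no direction for this assay . Compound 2 and compound 3 both carry the naphthalen-1-yl group that enters in compound 4, and both stay at the limit.

On that basis compound 4 is expected to sit at 64 ug/mL, estimated to lie between 32 ug/mL and 128 ug/mL, with a fair chance that again only a limit is reported. This expectation rests on compound 2 with its limit of > 64 ug/mL. It rests equally on compound 3 with its limit of > 64 ug/mL.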

Compound 4, half-maximal cytotoxic concentration: 30.4 ug/mL
Estimate against measurement, compound 4: 2.1-fold (0.32 log units) above, outside the stated range (below it).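

Among the compounds shown here, no new step can be read: in this assay compound 4 gives 30.4 ug/mL, while compound 1 reads "nd" (no result reported), which leaves no pair of numbers to compare. The compounds shown leave open what naphthalen-1-yl in place of 2,5-difluorophenyl changes in this assay, with one firm point besides compound 4: the limit of > 64 ug/mL in this assay, at which 2 of the 4 values shown sit.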